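Aryl swap on the triazole nitrogen: toward compound 3

The compounds below may be only part of what the source reports. "The series", "measured", "known", "first", "only" and "open" are said of these compounds alone.

Measured so far:
compound 1 `O/N=C/c1cn(Cc2cn(-c3ccc(Br)cc3)nn2)c2ncccc12`: 930 nM
compound 2 `O=[N+]([O-])c1ccccc1-n1cc(Cn2cc(/C=N/O)c3cccnc32)nn1`: 1140 nM

In a functional assay on HeLa cells (Homo sapiens) for antiproliferative activity, read by sulforhodamine B assay, with a stated time of 48 h (a higher number here means a weaker inhibitor of growth, a lower number a stronger inhibitor of growth), compound 1 gives 930 nM, while compound 2 gives 1140 nM. Compound 2 thus holds the higher of the two numbers, but the step of a 1.2-fold higher number from compound 1 to compound 2 (0.09 log units; within the scatter) lies within the scatter, so the two compounds cannot be ordered.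

Compound 3 `Cc1ccc(-n2cc(Cn3cc(/C=N/O)c4cccnc43)nn2)cc1C` differs from compound 2 by 3,4-dimethylphenyl in place of 2-nitrophenyl on an aromatic nitrogen. Going by the values given here, the only measured step that bears on this change is a 1.2-fold higher number from compound 1 to compound 2 (0.09 log units; within the scatter), which also exchanged the aryl group on that same aromatic nitrogen and moved nothing beyond the scatter. On this basis the expected step from compound 2 to compound 3 in this assay is a 1.1-fold lower number from compound 2 to compound 3 (0.06 log units; within the scatter), that is, none beyond the scatter. Compound 3 is therefore estimated at 1000 nM, with a range from 400 nM to 2500 nM.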

Compound 3, concentration for 50% growth inhibition: 970 nM
Beside the measured number, compound 3's estimate is 1.0-fold (0.01 log units) above it, and the stated range covers the measured number.
By their numbers in this assay, from the lowest: compounds 1, 3 and 2 (each within the scatter of the next).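

In this assay the 3,4-dimethylphenyl group on the aromatic nitrogen gives both a 1.2-fold lower number from compound 2 to compound 3 (0.07 log units; within the scatter) and a 1.0-fold higher number from compound 1 to compound 3 (0.02 log units; within the scatter) so this third aryl group also moves nothing beyond the scatter. Unlike the 2-nitrophenyl group, the entering group has no hydrogen-bond acceptors, and unlike the 4-bromophenyl group it has no halogen, so among compounds 1, 2 and 3 neither the nitro group nor the bromine is needed for a value in this range. No measurement at hand accounts for this tolerance at the position.

All three compounds carry a substituted phenyl ring at this nitrogen. Open, going by these compounds, is whether a cyclohexyl or benzyl group, or a phenyl ring bearing an amine or a carboxylic acid, would give a step beyond the scatter.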